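Pyridin-4-yl amide in the dimethoxy series: expected edema inhibition

The source may hold more compounds than are shown below. What is called first, only, known or untested is meant among the compounds shown, and "the series" means these compounds.

Among the measured compounds shown here, compound 1 `COc1cc2c(cc1OC)C(CC(=O)Nc1ccccc1C)CC2` gives 25.9% in a functional assay on the whole organism (strain Wistar) for inhibition, with Rattus norvegicus as the target, read by paw edema, with a stated time of 6 h, at a dose of 100 mg/kg (on this read-out lower numbers stand for less inhibition and higher numbers for more inhibition at the one dose given (going by the name of the read-out)), and stands lowest of the three numbers so far. Compound 2 `COc1cc2c(cc1OC)C(CC(=O)Nc1cccc(C)c1)CC2` gives 38% and compound 3 `COc1cc2c(cc1OC)C(CC(=O)Nc1ccc([N+](=O)[O-])cc1)CC2` gives 37% in this assay. For the measured compounds named here, the one measured step, a number 12.1 percentage points higher from compound 1 to compound 2 (beyond the scatter), moves away from 2-methylphenyl on the amide-type nitrogen and is a modest rise. Compound 4 `COc1cc2c(cc1OC)C(CC(=O)Nc1ccncc1)CC2` differs from compound 1 by pyridin-4-yl in place of 2-methylphenyl on an amide-type nitrogen. Going by the values given here, no measured step exchanges a carbon ring for a ring with a hetero atom, so the only bearing is that leaving 2-methylphenyl gave a modest rise in this assay. A modest rise beyond the scatter is therefore expected, a number 9.1 percentage points higher from compound 1 to compound 4 (within the scatter). Compound 4 is estimated at 35%, within 22% to 48%.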

Compound 4, a percentage reported as inhibition, in the whole organism at one dose (the size of the read-out at that dose, not a potency): 46.3%
Beside the measured number, compound 4's estimate is 11.3 percentage points below it, and the stated range covers the measured number.
By their numbers in this assay, from the lowest: compound 1; then compounds 3, 2 and 4 (each within the scatter of the next).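

In this assay, pyridin-4-yl in place of 2-methylphenyl on the amide-type nitrogen gives a number 20.4 percentage points higher from compound 1 to compound 4 (beyond the scatter) and so shows that a ring with a hetero atom is accepted at this position. Pyridin-4-yl in place of 3-methylphenyl gives a number 8.3 percentage points higher from compound 2 to compound 4 (within the scatter) and so does not separate the ring nitrogen from the simple loss of 2-methylphenyl. No available evidence explains either step.

Open, on these data alone, is how a saturated ring such as piperidine or a carboxylic acid on this nitrogen would read, and whether the order holds at other doses.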